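The source may report more compounds than this note shows. Statements on the series, on what has been measured and on what is new or still open speak of the compounds shown alone.

Compound 1 `N#CCCCn1c(Cn2c(=O)n(-c3ccc(C(=O)NC4CC4)cc3)c3ccncc32)cc2cc(Cl)ccc21` — > 50000 nM
Compound 2 `Cn1ccc(-n2c(=O)n(Cc3cc4cc(Cl)ccc4n3CCCC#N)c3cnccc32)n1` — > 50000 nM

In an ADME assay on HeLa cells (Homo sapiens) for cytotoxicity, read by ATP content, with a stated time of 3 days (a higher number here means that more compound is tolerated, a lower number that less compound is tolerated), compound 1 gives > 50000 nM, which is a limit of the assay and not a number. Compound 2 gives > 50000 nM in this assay, again a limit rather than a number. Both readings fall on (the limit of > 50000 nM in this assay, at which 2 of the 2 values shown sit). The step that the two limits leave unreadable from compound 1 to compound 2 therefore has no readable size; it swaps 1-methyl-1H-pyrazol-3-yl for 4-(cyclopropylcarbamoyl)phenyl on an aromatic nitrogen. Compound 3 `N#CCCCn1c(Cn2c(=O)n(-c3ncco3)c3ccncc32)cc2cc(Cl)ccc21` has not yet been measured; it differs from compound 2 by 1,3-oxazol-2-yl in place of 1-methyl-1H-pyrazol-3-yl on an aromatic nitrogen. For the measured compounds named here, the only measured step touching this aromatic nitrogen is the unreadable one, so the measured compounds give no size of step to lean on. With both known values sitting at the limit, compound 3 is expected to stay at the limit as well, which amounts to an expected step of a number no higher from compound 2 to compound 3 (the limit leaves the size open). Compound 3 is thus estimated at 50000 nM, within 20000 nM to 120000 nM.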

Compound 3, half-maximal cytotoxic concentration: > 50000 nM
Compound 3 ended at the assay's limit; the forecaster's own chance of this, stated with the estimate: 85%; the middle value sits exactly at the limit.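

No step among compound 1, compound 2 and compound 3 can be read, since each result in this assay is a limit of the assay and not a number: the limit of > 50000 nM in this assay, at which 3 of the 3 values shown sit.

From the compounds shown here alone, whether the three groups on the aromatic nitrogen differ at all in this assay stays open.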